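A Methoxy Removed from a Potent Nicotinic Receptor Ligand

The source may hold more compounds than are shown below. What is called first, only, known or untested is meant among the compounds shown, and "the series" means these compounds.

Compound 1 `COc1ccc(Nc2cncc(N3CC4CC(C3)N4)c2)cc1`: 0.0598 nM
Compound 2 `CN(c1ccccc1)c1ccc(N2CC3CC(C2)N3)nn1`: 1430 nM

In an assay on cell membranes for displacement of a labelled ligand from Neuronal acetylcholine receptor; alpha4/beta2 (Rattus norvegicus) (on this read-out lower numbers stand for stronger inhibition and higher numbers for weaker inhibition), compound 1 gives 0.0598 nM, the lowest of the two numbers, while compound 2 gives 1430 nM, a gap well beyond the scatter. Compound 3 `c1ccc(Nc2cncc(N3CC4CC(C3)N4)c2)cc1` has not yet been measured. It differs from compound 1 in one place: hydrogen in place of methoxy on an aromatic carbon. Within the data shown here, no measured pair shows this change, so the expected step of a 2.0-fold higher number from compound 1 to compound 3 (0.30 log units; within the scatter) is small, a slight weakening at most, possibly within the scatter. Compound 3 is therefore expected to give 0.12 nM, with a range from 0.025 nM to 0.6 nM.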

Compound 3, inhibition constant: 0.0807 nM
The estimate for compound 3 lay 1.5-fold (0.17 log units) above the measured number; measured number inside the range.
By their numbers in this assay, from the lowest: compounds 1 and 3 (each within the scatter of the next); then compound 2.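

In this assay, replacing the methoxy with hydrogen on this aromatic carbon gives a 1.3-fold higher number from compound 1 to compound 3 (0.13 log units; within the scatter), so the swap leaves the number within the scatter. The methoxy is therefore not needed for a very low number here, as compound 3 still gives 0.0807 nM and keeps the rest of compound 1 unchanged. Nothing available explains why this swap changes so little. Going by these compounds, what remains open is how other groups on this same carbon, such as an amine, a carboxylic acid or a longer alkoxy chain, would behave.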